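Swapping the nitrile for a cyclopentylamino group

A few compounds are considered here, and "the series" means these few. Any claim that something is new, unique, unknown or untested is made for them only; others in the source may bear on it.

Of the compounds shown here, three built on one shared core have been measured in a functional assay for antagonist activity at transient receptor potential cation channel subfamily V member 1 (Rattus norvegicus); on this read-out higher numbers stand for weaker inhibition and lower numbers for stronger inhibition. Compound 1 `CC(C)(C)c1ccc(NC(=O)c2ccc(-c3ncccc3F)cc2)cc1` gives 1 nM. Compound 2 `CCCOc1cccnc1-c1ccc(C(=O)Nc2ccc(C(C)(C)C)cc2)cc1` gives 20 nM. Compound 3 `CC(C)(C)c1ccc(NC(=O)c2ccc(-c3ncccc3C#N)cc2)cc1` gives 13 nM, which places it second highest of the three numbers: it sits within the scatter of compound 2, and far from compound 1, since the step of a 13-fold higher number from compound 1 to compound 3 (1.11 log units; beyond the scatter) lies well beyond the scatter.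

Compound 4 `CC(C)(C)c1ccc(NC(=O)c2ccc(-c3ncccc3NC3CCCC3)cc2)cc1` has not yet been measured. It differs from compound 3 in one place: cyclopentylamino in place of cyano on an aromatic carbon.

Among the measured compounds shown here, two measured steps bear on this. Replacing fluoro with a larger group at this same carbon raised the number strongly in both cases: a 20-fold higher number from compound 1 to compound 2 (1.30 log units; beyond the scatter) and a 13-fold higher number from compound 1 to compound 3 (1.11 log units; beyond the scatter). Between the two larger groups, however, the step of a 1.5-fold lower number from compound 2 to compound 3 (0.19 log units; within the scatter) stayed within the scatter, so the size of the group beyond fluoro did not separate compound 2 from compound 3. Cyclopentylamino is larger again, and brings a hydrogen-bond donor that neither propoxy nor cyano carries, for which no measured step exists.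

Compound 4 is therefore expected to land near compound 3 or somewhat higher, an estimated step of a 2.3-fold higher number from compound 3 to compound 4 (0.36 log units; beyond the scatter). The estimate for compound 4 in this assay is 30 nM, with a range from 8 nM to 120 nM.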

Compound 4, half-maximal inhibitory concentration: 44 nM
For compound 4 the middle estimate is 1.5-fold (0.17 log units) below the measured one, within the range that was stated.
By their numbers in this assay, from the lowest: compound 1; then compounds 3 and 2 (each within the scatter of the next); then compound 4.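

Putting cyclopentylamino on this aromatic carbon separates a larger group from the earlier ones, which propoxy and cyano did not do among themselves: in this assay the data show a 3.4-fold higher number from compound 3 to compound 4 (0.53 log units; beyond the scatter) and a 2.2-fold higher number from compound 2 to compound 4 (0.34 log units; beyond the scatter), and both steps lie beyond the scatter. These two steps are modest, while a 44-fold higher number from compound 1 to compound 4 (1.64 log units; beyond the scatter) is large, so compound 4 carries the highest number of the four, and most of that distance is already present in the large steps from fluoro to propoxy and to cyano. No measurement shown gives a reason for this rise.

Cyclopentylamino adds both a five-membered carbon ring and a hydrogen-bond donor, so these compounds leave open which of the two goes with the higher number; a plain amino group and a cyclopentyloxy group on the same carbon would pull the two apart. From the compounds shown here alone, it also remains open whether any group other than fluoro, such as chloro or methyl, can hold a number as low as that of compound 1 at this carbon.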